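The source may report more compounds than this note shows. Statements on the series, on what has been measured and on what is new or still open speak of the compounds shown alone.

Values in a functional assay on the whole organism for antagonist activity, with Mus musculus as the target; a lower number here means that less compound is needed, a higher number that more compound is needed for the effect:
- Compound 1 `COC(=O)N(C)CC#CCn1ccnc1`: > 100 mg/kg (a limit)
- Compound 2 `COC(=O)N(C)CC#CCn1cncc1C`: 3 mg/kg
- Compound 3 `COC(=O)N(C)CC#CCN(C)C`: > 30 mg/kg (a limit)

Compound 1 is known only by a limit, > 100 mg/kg. Compound 4 `COC(=O)N(C)C(C)C#CCn1ccnc1` departs from it by one change, methyl in place of hydrogen on a saturated chain carbon bound to an amide-type nitrogen and a triple-bonded carbon.

Two measured steps start from compound 1. The one that bears most closely is an at least 33-fold lower number from compound 1 to compound 2 (1.52 log units; beyond the scatter). It is also a methyl in place of hydrogen, but on an aromatic carbon, so it is a guide and not a precedent. The other, a step that the two limits leave unreadable from compound 1 to compound 3, gives no size to work with. Among the compounds with values here, no measured step touches the chain carbon itself.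

Within the data shown here, with compound 2 as the only guide, through its value of 3 mg/kg, a lower number is expected in this assay, though probably by less than that step. The expected change is an at least 3.3-fold lower number from compound 1 to compound 4 (0.52 log units; beyond the scatter). For compound 4 the estimated value is 30 mg/kg, with an expected range from 6 mg/kg to 150 mg/kg.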

Compound 4, dose for half-maximal effect: > 100 mg/kg
Compound 4 was reported as a limit; the forecaster's own chance of this, stated with the estimate: 45%; at least 3.3-fold (0.52 log units) between middle value and limit.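

In this assay compound 4 is reported only as a limit, > 100 mg/kg. Compound 1 is also known only as a limit, so the step between these two compounds cannot be read. The compounds shown leave open whether the added methyl on the saturated chain carbon changes the dose needed at all.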